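The compounds below may be only part of what the source reports. "The series", "measured", "known", "first", "only" and "open" are said of these compounds alone.

Measured in a functional assay on HT-29 cells (Homo sapiens) for cytotoxicity, read by MTT assay, with a stated time of 48 h; a higher number here means a weaker inhibitor, a lower number a stronger inhibitor:
- Compound 1 `CS(=O)(=O)c1ccc(Cc2nnc3n2N=C(c2ccccc2)CS3)cc1`: 25000 nM
- Compound 2 `CS(=O)(=O)c1ccc(Cc2nnc3n2N=C(c2ccc(-c4ccccc4)cc2)CS3)cc1`: 12500 nM
- Compound 3 `CS(=O)(=O)c1ccc(Cc2nnc3n2N=C(c2cc(Cl)sc2Cl)CS3)cc1`: > 100000 nM (a limit, not a number)

Compound 3 has no exact number and stands at the limit of > 100000 nM in this assay, at which 1 of the 3 values shown sits.

Compound 4 `Cc1ccc(C2=Nn3c(Cc4ccc(S(C)(=O)=O)cc4)nnc3SC2)cc1` differs from it in one group, with 4-methylphenyl in place of 2,5-dichlorothiophen-3-yl on a carbon with a double bond to nitrogen. The closest measured change runs the other way: 2,5-dichlorothiophen-3-yl in place of phenyl gave an at least 4.0-fold higher number from compound 1 to compound 3 (0.60 log units; beyond the scatter). Phenyl in place of hydrogen on an aromatic carbon gave a 2.0-fold lower number from compound 1 to compound 2 (0.30 log units; within the scatter), so an added group on that ring may matter little here. A lower number of at least modest size is therefore expected in this assay. The estimated step is an at least 5.0-fold lower number from compound 3 to compound 4 (0.69 log units; beyond the scatter). The expected value for compound 4 is 20000 nM, with an estimated range of 8000 nM to 60000 nM.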

Compound 4, half-maximal inhibitory concentration: > 100000 nM
Compound 4 ended at the assay's limit; the forecaster's own chance of this, stated with the estimate: 10%; middle value at least 5.0-fold (0.69 log units) away from the limit.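

In this assay, the ring at this position turns out to be sensitive to what it carries: methyl in place of phenyl gives an at least 8.0-fold higher number from compound 2 to compound 4 (0.90 log units; beyond the scatter), and methyl in place of hydrogen gives an at least 4.0-fold higher number from compound 1 to compound 4 (0.60 log units; beyond the scatter). Among the compounds shown here, a single added group on that ring can therefore move the number beyond the scatter, which the earlier compounds did not show. The step from compound 3 to compound 4 cannot be read, since each value is only a limit: the limit of > 100000 nM in this assay, at which 2 of the 4 values shown sit.

From the compounds shown here alone, how an amine or a carboxylic acid in place of that methyl would read stays open. So does whether any group other than phenyl on that ring keeps the number measurable.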